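Fluorine on the pendant phenyl, carried across two cores

A few compounds are considered here, and "the series" means these few. Any claim that something is new, unique, unknown or untested is made for them only; others in the source may bear on it.

Compound 1 `O=C(CSc1nc2c(c(=O)n1-c1ccccc1)SCC2)Nc1nc2ccc(C(F)(F)F)cc2s1` gives 40 nM in an assay on L cells for inhibition of Protein-serine O-palmitoleoyltransferase porcupine (Mus musculus), read by reporter gene assay, with a stated time of 24 h; on this read-out lower numbers stand for an effect already at smaller amounts and higher numbers for an effect only at larger amounts of compound. Compound 3 `O=C(CSc1nc2c(c(=O)n1-c1ccc(F)cc1)SCC2)Nc1nc2ccc(C(F)(F)F)cc2s1` differs from compound 1 by fluoro in place of hydrogen on an aromatic carbon and in this assay compound 3 gives 100 nM, a step of a 2.5-fold higher number from compound 1 to compound 3 (0.40 log units; beyond the scatter). Compound 2 `O=C(CNC(=O)c1nn(-c2ccccc2)c(=O)c2ccccc12)Nc1nc2ccc(C(F)(F)F)cc2s1` rests on another core; the difference between the two cores is not broken down here. In this assay compound 2 gives 110 nM, a number that lies within the scatter of that of compound 3. Compound 4 `O=C(CNC(=O)c1nn(-c2ccc(F)cc2)c(=O)c2ccccc12)Nc1nc2ccc(C(F)(F)F)cc2s1` is not yet measured; it differs from compound 2 by fluoro in place of hydrogen on an aromatic carbon, the same change at the same place as from compound 1 to compound 3. The step from compound 2 to compound 4 is expected to be a 2.3-fold higher number from compound 2 to compound 4 (0.36 log units; beyond the scatter), which rests on a 2.5-fold higher number from compound 1 to compound 3 (0.40 log units; beyond the scatter) seen once, with the core change untested. Compound 4 is therefore estimated at 250 nM, between 120 nM and 550 nM.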

Compound 4, half-maximal effective concentration: 90 nM
Compound 4: the middle estimate sits 2.8-fold (0.44 log units) above what was measured, outside the stated range (below it).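

On the core of compound 2, phenyl to 4-fluorophenyl gives a 1.2-fold lower number from compound 2 to compound 4 (0.09 log units; within the scatter), so the step seen on the core of compound 1 does not carry over to this core in this assay: the same change on two cores in this assay, a 2.5-fold higher number (0.40 log units; beyond the scatter) from compound 1 to compound 3 and a 1.2-fold lower number (0.09 log units; within the scatter) from compound 2 to compound 4, 3.1-fold (0.49 log units) apart, beyond the scatter of two such steps. For these two pairs, then, the step on one core cannot stand in for the step on the other. This does not show why the two steps differ or how the change would read on a third core, and each core rests on a single pair.

Still open, from the compounds shown here alone, is how a chlorine, a methoxy group or an amine at the same place on the phenyl would read on each core. Also open, going by these compounds, is whether the two cores would again part with a replacement for the trifluoromethyl group.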